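Trifluoromethyl for methyl, repeated on a second core

This account rests on a few compounds, and the source may have more. Where it says the series, first, only, none or still open, it means among the compounds named here.

The three measured compounds, all tested in a functional assay on HeLa cells (Homo sapiens) for antiproliferative activity, read by MTT assay, with a stated time of 48 h; a lower number here means a stronger inhibitor of growth, a higher number a weaker inhibitor of growth:

compound 1, `CCOC(=O)c1sc2ccc(NCc3c[nH]cn3)cc2c1NC(=O)c1ccc(C)cc1`, compound 1 gives 11700 nM
compound 2, `CCOC(=O)c1sc2ccc(NCc3c[nH]cn3)cc2c1NC(=O)c1ccc(C(F)(F)F)cc1`, compound 2 gives 16800 nM
compound 3, `CCOC(=O)c1sc2ccc(N)cc2c1NC(=O)c1ccc(C)cc1`, compound 3 gives 24400 nM

Compound 1 and compound 2 share one core and differ in one place: trifluoromethyl in place of methyl on an aromatic carbon. In this assay that change gave a 1.4-fold higher number from compound 1 to compound 2 (0.16 log units; within the scatter), so the two numbers cannot be told apart with confidence.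

Compound 3 carries a different core, and the difference from compound 1 is hydrogen in place of (1H-imidazol-4-yl)methyl on a nitrogen on an aromatic ring. This change gave a 2.1-fold higher number from compound 1 to compound 3 (0.32 log units; beyond the scatter), a modest step, and compound 3 holds the highest of the three numbers.

Compound 4, `CCOC(=O)c1sc2ccc(N)cc2c1NC(=O)c1ccc(C(F)(F)F)cc1`, has not yet been measured. It stands to compound 3 as compound 2 stands to compound 1: trifluoromethyl in place of methyl on an aromatic carbon. The place is described in the same words for both pairs, so this is the same change made on the second core.

The expectation for compound 4 in this assay rests on one pairing only. Because the change gave a 1.4-fold higher number from compound 1 to compound 2 (0.16 log units; within the scatter) on the core of compound 1, the step from compound 3 to compound 4 is estimated at a 1.4-fold higher number from compound 3 to compound 4 (0.14 log units; within the scatter), a step that would again fall within the usual scatter. Compound 4 is therefore expected to give about 34000 nM in this assay, with a plausible range from 17000 nM to 70000 nM.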

Compound 4, concentration for 50% growth inhibition: 6680 nM
Compound 4: middle estimate off by 5.1-fold (0.71 log units), on the high side, and the stated range ends above it.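

In this assay, trifluoromethyl in place of methyl gave a 3.7-fold lower number from compound 3 to compound 4 (0.56 log units; beyond the scatter), a step beyond the scatter, whereas the same change on the core of compound 1 stayed within it, so the step measured on one core did not carry over to the other: the same change on two cores in this assay, a 1.4-fold higher number (0.16 log units; within the scatter) from compound 1 to compound 2 and a 3.7-fold lower number (0.56 log units; beyond the scatter) from compound 3 to compound 4, 5.2-fold (0.72 log units) apart, beyond the scatter of two such steps

The same square read along its other side gives a 2.5-fold lower number from compound 2 to compound 4 (0.40 log units; beyond the scatter), while the matching step between the methyl compounds ran the other way, so the effect of hydrogen in place of (1H-imidazol-4-yl)methyl on the nitrogen also depends on the group at the far end of the molecule: the same change on two cores in this assay, a 2.1-fold higher number (0.32 log units; beyond the scatter) from compound 1 to compound 3 and a 2.5-fold lower number (0.40 log units; beyond the scatter) from compound 2 to compound 4, 5.2-fold (0.72 log units) apart, beyond the scatter of two such steps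

This shows that the two changes did not add up independently across these four compounds, but it rests on a single square in a single assay, so it does not show why they interact or how a step would behave on any further core.

The compounds shown leave open whether a chlorine or a methoxy group in place of trifluoromethyl would follow the pattern of compound 4 on the core with hydrogen on the nitrogen. They also leave open whether a benzyl or an acetyl group on that nitrogen would behave like (1H-imidazol-4-yl)methyl or like hydrogen.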